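Chloro for Methyl: What to Expect of Compound 3

This account rests on a few compounds, and the source may have more. Where it says the series, first, only, none or still open, it means among the compounds named here.

Compound 1 `Cc1ccccc1-n1cc(-c2ccccc2NS(=O)(=O)c2c[nH]c(=O)[nH]c2=O)nn1` was tested in a functional assay on SGC-7901 cells (Homo sapiens) for antiproliferative activity, read by MTT assay, with a stated time of 24 h (a higher number here means a weaker inhibitor, a lower number a stronger inhibitor), where compound 1 gives 9570 nM. Within the data shown here, of the two numbers recorded so far this is the higher one; its only neighbour is compound 2 `Cc1ccc(-n2cc(-c3ccccc3NS(=O)(=O)c3c[nH]c(=O)[nH]c3=O)nn2)cc1`, which in this assay gives 6390 nM. The step of a 1.5-fold lower number from compound 1 to compound 2 (0.18 log units; within the scatter) stays within the scatter, so on these data the two compounds cannot be told apart.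

Compound 3 `O=c1[nH]cc(S(=O)(=O)Nc2ccccc2-c2cn(-c3ccccc3Cl)nn2)c(=O)[nH]1` differs from compound 1 by chloro in place of methyl on an aromatic carbon; cut one bond further out, 2-methylphenyl becomes 2-chlorophenyl, the change falling on a six-membered aromatic ring of carbon only, ortho to a large group. Among the measured compounds shown here, only one measured step can be brought to bear: a 1.5-fold lower number from compound 1 to compound 2 (0.18 log units; within the scatter), which moved the methyl rather than exchanging it, and lay within the scatter. For the measured compounds named here, no measured step swaps methyl for chloro, so the direction of such a swap is unknown here. On this thin basis the expectation is for no shift beyond the scatter, which the estimated step of a 1.1-fold lower number from compound 1 to compound 3 (0.03 log units; within the scatter) is meant to express. Compound 3 is therefore expected to give about 9000 nM, within a range from 4000 nM to 20000 nM.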

Compound 3, half-maximal inhibitory concentration: 6520 nM
Beside the measured number, compound 3's estimate is 1.4-fold (0.14 log units) above it, within the range that was stated.
By their numbers in this assay, from the lowest: compounds 2, 3 and 1 (each within the scatter of the next).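

Chloro in place of methyl on an aromatic carbon, ortho to a large group, gives a 1.5-fold lower number from compound 1 to compound 3 (0.17 log units; within the scatter) and so the first measured exchange of the group itself at this place stays within the scatter in this assay. The step 2-chlorophenyl in place of 4-methylphenyl on the aromatic nitrogen gives a 1.0-fold higher number from compound 2 to compound 3 (0.01 log units; within the scatter) and therefore 2-methylphenyl, 4-methylphenyl and 2-chlorophenyl cannot be told apart on these numbers, which extends the earlier finding from a moved methyl to a different group. No measurement of any property of these groups accompanies the result, so the data offer no explanation for how closely the three compounds sit together.

The compounds shown leave open whether a group of another kind on this six-membered aromatic ring, such as an amine, a carboxylic acid or a longer alkyl chain, would shift the number beyond the scatter. Also open, from the compounds shown here alone, is whether any change to the shared core itself would do so, since all three compounds keep it intact and differ only in the group on the aromatic nitrogen.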